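Cyclopentyl in place of cyclopropyl: compound 4

The compounds below may be only part of what the source reports. "The series", "measured", "known", "first", "only" and "open" are said of these compounds alone.

Three compounds of the series have been run in a functional assay on the whole organism (plasma, strain Sprague-Dawley) with Rattus norvegicus as the target, with a stated time of 2 h, at a dose of 100 mg/kg by the oral route; on this read-out lower numbers stand for a weaker effect and higher numbers for a stronger effect at the one dose given. Compound 1 `c1ccc(C(/N=C2\CCCCCN2)C2CC2)cc1` gives 51%, the second highest of the three numbers. Compound 3 `Cc1ccc(C(/N=C2\CCCCCCCN2)C2CC2)c(C)c1` gives 61%, and this lies within the scatter of the number for compound 1. Among the measured compounds shown here, compound 2 `COc1ccc(C(/N=C2\CCCCCN2)C2CC2)cc1` gives 40%; the step of a number 11 percentage points lower from compound 1 to compound 2 (beyond the scatter) is the only measured step between compounds that differ in one place. For the measured compounds named here, no measured pair bears on the saturated carbocycle at the saturated chain carbon.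

Compound 4 `c1ccc(C(/N=C2\CCCCCN2)C2CCCC2)cc1` has not been measured. It differs from compound 1 in one place: cyclopentyl in place of cyclopropyl on a saturated chain carbon bound to an aromatic carbon and a double-bonded nitrogen. Compound 3 carries a different core and a different aromatic substitution, so its value cannot be read as a guide to this change. With nothing in the measured steps speaking to it, no step beyond the scatter is expected, and the step from compound 1 to compound 4 is estimated as a number 1 percentage points lower from compound 1 to compound 4 (within the scatter). The estimate for compound 4 in this assay is 50%, with a range from 30% to 70%.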

Compound 4, a percentage reported as inhibition, in the whole organism at one dose (the size of the read-out at that dose, not a potency): 46%
Compound 4: the middle estimate sits 4 percentage points above what was measured; low and high end bracket the measured number.
By their numbers in this assay, from the lowest: compounds 2, 4, 1 and 3 (each within the scatter of the next, the first and the last beyond it).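

In this assay, among the compounds shown here, the replacement of cyclopropyl by cyclopentyl on a saturated chain carbon bound to an aromatic carbon and a double-bonded nitrogen comes out as a number 5 percentage points lower from compound 1 to compound 4 (within the scatter) and is the first measured step at this position. At this one dose the read-out therefore does not separate the two carbocycles, although cyclopentyl carries 5 heavy atoms against 3 for cyclopropyl. No measurement available here speaks to a cause for this outcome.

Going by these compounds, whether an open chain such as isopropyl, a phenyl ring or an amine at this carbon would move the number beyond the scatter remains open. On these data alone, it is also open whether cyclopentyl would give a similar result alongside the methoxy group of compound 2 or on the core of compound 3.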